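Compound 3 Waits at the Edge of the Assay

This account rests on a few compounds, and the source may have more. Where it says the series, first, only, none or still open, it means among the compounds named here.

Compound 1, `CC1=CC[C@@H]([C@@](C)(O)CCCC(C)(C)NC(=S)N/N=C\c2ccccc2)CC1`, was tested in a functional assay on K562 cells (Homo sapiens) for cytotoxicity, read by sulforhodamine B assay; a lower number here means that less compound is tolerated, a higher number that more compound is tolerated. In this assay compound 1 gives > 100000 nM, which is a limit of the assay rather than a number. Among the measured compounds shown here, its only measured neighbour is compound 2, `CC1=CC[C@@H]([C@@](C)(O)CCCC(C)(C)NC(=S)N/N=C\c2ccccc2[N+](=O)[O-])CC1`, which differs from it at a single point. In this assay compound 2 gives > 100000 nM, again a limit. The step that the two limits leave unreadable from compound 1 to compound 2 therefore cannot be read, and the limit of > 100000 nM in this assay, at which 2 of the 2 values shown sit, is all the evidence the pair offers.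

Compound 3, `CC1=CC[C@@H]([C@@](C)(O)CCCC(C)(C)NC(=S)N/N=C(/C)c2ccccc2)CC1`, has not yet been measured. It differs from compound 1 by a group of 9 heavy atoms (8 carbon, 1 nitrogen; one six-membered aromatic ring of carbon only) in place of a group of 8 heavy atoms (7 carbon, 1 nitrogen; one six-membered aromatic ring of carbon only), on an amide-type nitrogen. For the measured compounds named here, no measured step covers a change of this kind on the amide-type nitrogen, and both values available sit at the limit, so no step in either direction beyond the scatter can be predicted; the expectation is simply that compound 3 will also pass what the assay can report. Compound 3 is therefore expected to give 100000 nM, within 30000 nM to 300000 nM, which amounts to an expected step of a number no higher from compound 1 to compound 3 (the limit leaves the size open).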

Compound 3, concentration lethal to 50% of the cells: 1540 nM
For compound 3 the middle estimate is 65-fold (1.81 log units) above the measured one; measured number outside the range, below it.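

With compound 3 the position on an amide-type nitrogen becomes the first place in this series where this assay gives a readable response, with an at least 64-fold lower number from compound 1 to compound 3 (1.81 log units; beyond the scatter) and a number that lies inside what the assay can report. The change is small in its counts, a group of 9 heavy atoms (8 carbon, 1 nitrogen; one six-membered aromatic ring of carbon only) in place of a group of 8 heavy atoms (7 carbon, 1 nitrogen; one six-membered aromatic ring of carbon only), yet it is enough to bring the compound off the limit. The step from compound 1 to compound 2 still cannot be read, so the nitro change cannot be set against this one, and the limit remains the reading for most of the series: the limit of > 100000 nM in this assay, at which 2 of the 3 values shown sit.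

Going by these compounds, the true size of the step stays open, since one end of it is a limit. Also open, on these data alone, is whether an ethyl group or a longer chain in the entering group would carry the change further, and whether a nitro group on the aromatic ring of compound 3 would alter its number.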